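The source may report more compounds than this note shows. Statements on the series, on what has been measured and on what is new or still open speak of the compounds shown alone.

In an ADME assay on tissue (MIA PaCa-2 cells, Homo sapiens) for pharmacokinetics (a higher number here means that the compound lasts longer, a lower number that the compound disappears faster), compound 1 `N[C@@H](CC(=O)OC[C@H]1O[C@@H](n2cc(F)c(=O)[nH]c2=O)C[C@@H]1O)C(=O)O` gives 0.273 h and compound 2 `N[C@@H](CC(=O)OC[C@H]1O[C@@H](n2cc(F)c(=O)[nH]c2=O)C[C@@H]1OC(=O)C[C@H](N)C(=O)O)C(=O)O` gives 0.188 h, so the two stand level within the scatter. Compound 3 `N[C@@H](CCC(=O)OC[C@H]1O[C@@H](n2cc(F)c(=O)[nH]c2=O)C[C@@H]1O)C(=O)O` differs from compound 1 by one change, 2-amino-2-carboxyethyl in place of amino(carboxy)methyl on a saturated chain carbon bound to a carbonyl carbon. Among the compounds with values here, the only measured step, a 1.5-fold lower number from compound 1 to compound 2 (0.16 log units; within the scatter), lies at another place and is small, so no step beyond the scatter is expected in this assay. The estimated step is a 1.1-fold lower number from compound 1 to compound 3 (0.04 log units; within the scatter). Compound 3 is expected at 0.25 h, within a range of 0.12 h to 0.5 h.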

Compound 3, half-life: 0.335 h
Beside the measured number, compound 3's estimate is 1.3-fold (0.13 log units) below it; the range from low to high includes it.
By their numbers in this assay, from the lowest: compounds 2, 1 and 3 (each within the scatter of the next).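

At this position, 2-amino-2-carboxyethyl in place of amino(carboxy)methyl on a saturated chain carbon bound to a carbonyl carbon gives a 1.2-fold higher number from compound 1 to compound 3 (0.09 log units; within the scatter) in this assay. Within the data shown here, this is the first reading at this place, and it shows that the half-life stays level within the scatter under this change. Nothing on hand offers an explanation for this result. From the compounds shown here alone, whether a longer chain, or a chain bearing an amine but no carboxylic acid, would move the half-life beyond the scatter stays open.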